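Swapping isobutyl for cyclohexyl on a ring amine

The source may report more compounds than this note shows. Statements on the series, on what has been measured and on what is new or still open speak of the compounds shown alone.

Of the compounds shown here, two sharing one core have so far been tested in an assay on HEK293 cells for binding affinity to 5-hydroxytryptamine receptor 7 (Homo sapiens), read by radioligand binding; on this read-out higher numbers stand for weaker inhibition and lower numbers for stronger inhibition. Compound 1 `CC(C)c1ccc2ccn(CCN3CCCN(C)CC3)c2c1` gives 145 nM in this assay. Compound 2 `CC(C)CN1CCCN(CCn2ccc3ccc(Br)cc32)CC1` gives 37 nM in this assay, the lowest of the two numbers; the gap to compound 1 is beyond the scatter of the measurement, so compound 2 binds more tightly. The next compound, compound 3 `Brc1ccc2ccn(CCN3CCCN(C4CCCCC4)CC3)c2c1`, is built from compound 2 by a single change: cyclohexyl in place of isobutyl on an amine nitrogen in a ring. Among the compounds with values here, no comparable step between measured compounds is available, so the size of this change has to be estimated from the structures alone. The step from compound 2 to compound 3 is expected to be small, probably within the scatter, and if anything toward a lower number, as a 1.2-fold lower number from compound 2 to compound 3 (0.09 log units; within the scatter). Compound 3 is thus expected to give about 30 nM in this assay, with a plausible range from 8 nM to 120 nM.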

Compound 3, inhibition constant: 17 nM
The estimate for compound 3 lay 1.8-fold (0.25 log units) above the measured number, and the stated range covers the measured number.
By their numbers in this assay, from the lowest: compound 3; then compound 2; then compound 1.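

On the amine nitrogen in the seven-membered ring, cyclohexyl in place of isobutyl gives a 2.2-fold lower number from compound 2 to compound 3 (0.34 log units; beyond the scatter) in this assay, a step beyond the scatter. This position therefore accepts a larger carbon group that carries a ring of its own, and binding becomes tighter rather than weaker. Within the data shown here, compound 1 and compound 2 differ in more than one place, so only this step reads the group on this nitrogen by itself. Nothing available explains why the number falls with this change.

Still open, as far as these compounds go, is whether the ring itself matters or only the added carbons, which an open hexyl chain on the same nitrogen would help to separate. A phenyl ring or a chain ending in a hydroxyl group at this nitrogen would show how far the trend extends beyond these two carbon groups.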